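Swapping a pyridyl for an acetyl on a porcupine inhibitor

This account rests on a few compounds, and the source may have more. Where it says the series, first, only, none or still open, it means among the compounds named here.

Measured compounds:
- compound 1, `O=C(CSc1nc2c(c(=O)n1-c1ccccc1)SCC2)Nc1ccc(-c2ccccn2)cc1`: 4 nM
- compound 2, `CCOC(=O)c1ccc2nc(NC(=O)CNC(=O)c3nn(-c4ccccc4)c(=O)c4ccccc34)sc2c1`: > 25000 nM
- compound 3, `O=C(CSc1nc2c(c(=O)n1-c1ccccc1)SCC2)Nc1ccc(-c2cccs2)cn1`: 0.3 nM

In an assay on L cells for inhibition of Protein-serine O-palmitoleoyltransferase porcupine (Mus musculus), read by reporter gene assay, with a stated time of 24 h (on this read-out lower numbers stand for an effect already at smaller amounts and higher numbers for an effect only at larger amounts of compound), compound 1 gives 4 nM. Of the two plain numbers in this assay, compound 1 stands at the higher one; compound 3 gives 0.3 nM, a lower number, and the gap between them lies beyond the scatter. Compound 2 yields no number but only a limit, (the limit of > 25000 nM in this assay, at which 1 of the 3 values shown sits).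

Compound 4, `CC(=O)c1ccc(NC(=O)CSc2nc3c(c(=O)n2-c2ccccc2)SCC3)cc1`, has not been measured in this assay. It differs from compound 1 in one place: acetyl in place of pyridin-2-yl on an aromatic carbon. Going by the values given here, no measured pair shows this kind of swap, so the size of the step can only be guessed. The two measured actives both carry an aromatic ring at that end of the molecule; the acetyl is smaller and not a ring, so a step toward a higher number, beyond the scatter, is expected. For compound 4 the expected step is a 10-fold higher number from compound 1 to compound 4 (1.00 log units; beyond the scatter), and the estimate is 40 nM, with a range from 6 nM to 400 nM.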

Compound 4, half-maximal effective concentration: > 1000 nM
Compound 4: no number, only a limit; the forecaster's own chance of this, stated with the estimate: 5%; middle value at least 25-fold (1.39 log units) from the limit.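

In this assay, compound 4 gives only a limit, not a number: the limit of > 1000 nM in this assay, at which 1 of the 4 values shown sits.

Even so, the step can be read as an at least 250-fold higher number from compound 1 to compound 4 (2.39 log units; beyond the scatter), and it comes from acetyl in place of pyridin-2-yl on an aromatic carbon, para to a large group, with the rest of compound 1 unchanged. Going by these compounds alone, this is the first single-place change, and it shows that the group at this position has a large bearing on the read-out; the shared core alone does not give a low number.

Acetyl differs from pyridin-2-yl both in having no ring and in having fewer heavy atoms, so this one pair cannot separate the two differences. A phenyl ring at the same place, or a ring-free group of similar size such as a longer alkyl chain, would begin to tell them apart.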